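The source may report more compounds than this note shows. Statements on the series, on what has been measured and on what is new or still open speak of the compounds shown alone.

Measured so far:
compound 1, `C=CCn1c(SCC(=O)c2ccccc2)nnc1-c1ccccc1`, with 70% in a functional assay on the whole organism (strain albino) for inhibition, with Rattus norvegicus as the target, read by paw edema, with a stated time of 3 h, at a dose of 0.28 mmol/kg by the oral route; on this read-out lower numbers stand for less inhibition and higher numbers for more inhibition at the one dose given (going by the name of the read-out)
compound 2, `CCn1c(SCC(=O)c2ccccc2)nnc1-c1ccc(OC)cc1`, with 67% in this assay

Both compounds carry the same side chain on the shared core and differ in two places at once, the group on the ring nitrogen and the substituent on the pendant phenyl ring. In this assay compound 1 gives 70% and compound 2 gives 67%; the two numbers lie within the scatter of each other and cannot be told apart. Going by the values given here, compound 2 therefore stands level with the only other measured compound, with nothing in the pair to show a direction.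

Compound 3, `CCn1c(SCC(=O)c2ccccc2)nnc1-c1ccccc1`, is the next compound for this assay. It differs from compound 2 by hydrogen in place of methoxy on an aromatic carbon. Among the compounds with values here, no single-change step between measured compounds is available for this series, so the size of the change can only be expected, not read off.

With compound 1 and compound 2 level, and compound 3 sharing its ring-nitrogen group with compound 2 and its unsubstituted phenyl with compound 1, the step of a number 1 percentage points higher from compound 2 to compound 3 (within the scatter) is expected to stay within the scatter, with no clear direction. Compound 3 is estimated at 68% in this assay, in a range from 55% to 80%.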

Compound 3, a percentage reported as inhibition, in the whole organism at one dose (the size of the read-out at that dose, not a potency): 61%
The estimate for compound 3 lay 7 percentage points above the measured number; measured number inside the range.
By their numbers in this assay, from the lowest: compounds 3, 2 and 1 (each within the scatter of the next).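

Going by these compounds alone, compound 3 supplies the first single-change readings. At the place para to a large group on the six-membered aromatic ring, going from 4-methoxyphenyl to phenyl gives a number 6 percentage points lower from compound 2 to compound 3 (within the scatter) in this assay and so does not separate the methoxy compound from the unsubstituted one, while on the saturated chain carbon bound to an aromatic nitrogen, methyl in place of vinyl gives a number 9 percentage points lower from compound 1 to compound 3 (within the scatter) and likewise leaves the two compounds inseparable. Both groups can therefore be exchanged here without a change that stands clear of the scatter at this one dose, and nothing on hand explains either step.

As far as these compounds go, whether an amine or a carboxylic acid in place of methoxy, or a longer chain such as butyl on the ring nitrogen, would move the read-out beyond the scatter remains open. From the compounds shown here alone, the side chain with its carbonyl and phenyl is the same in all three compounds, so its contribution is also open, and a single dose gives no view of how the inhibition of paw edema would vary with dose.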